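Swapping the outer ring on a muscarinic receptor agonist scaffold

A few compounds are considered here, and "the series" means these few. Any claim that something is new, unique, unknown or untested is made for them only; others in the source may bear on it.

Measured compounds:
Compound 1 `O=C1C(=O)N(Cc2ccc(-c3ccccc3)cc2)c2ccc(OC(F)(F)F)cc21`: 2700 nM
Compound 2 `O=C1C(=O)N(Cc2ccc(-c3ccc(F)nc3)cc2)c2ccc(OC(F)(F)F)cc21`: 3600 nM
Compound 3 `Cn1cc(-c2ccc(CN3C(=O)C(=O)c4cc(OC(F)(F)F)ccc43)cc2)cn1`: 3300 nM

All three share one core and differ only in the outer aromatic ring; all three were tested in a functional assay on CHO cells for agonist activity at muscarinic acetylcholine receptor M5 (Homo sapiens), read by calcium flux; a higher number here means that more compound is needed for the effect, a lower number that less compound is needed. Compound 3 stands neither clearly above nor clearly below the other two: the step of a 1.2-fold higher number from compound 1 to compound 3 (0.09 log units; within the scatter) and the step of a 1.1-fold lower number from compound 2 to compound 3 (0.04 log units; within the scatter) are both within the scatter, as is a 1.3-fold higher number from compound 1 to compound 2 (0.12 log units; within the scatter). So far, then, exchanging the outer ring has not moved the number beyond what repeated testing would show anyway.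

Compound 4 `COc1ccccc1-c1ccc(CN2C(=O)C(=O)c3cc(OC(F)(F)F)ccc32)cc1` carries the change (2-methoxyphenyl in place of 1-methyl-1H-pyrazol-4-yl on an aromatic carbon), on an aromatic carbon of a six-membered aromatic ring of carbon only, para to a large group. The three earlier steps all bear on this change, since each also replaced that outer ring, and each stayed within the scatter. Compound 4 is therefore expected to give 3100 nM in this assay, with a range of 1200 nM to 8000 nM. The expected step is a 1.1-fold lower number from compound 3 to compound 4 (0.03 log units; within the scatter), no change beyond the scatter.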

Compound 4, half-maximal effective concentration: 3900 nM
Estimate against measurement, compound 4: 1.3-fold (0.10 log units) below; measured number inside the range.
By their numbers in this assay, from the lowest: compounds 1, 3, 2 and 4 (each within the scatter of the next).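

Even a 2-methoxyphenyl, with a carbon-only ring, an added methoxy and more heavy atoms than 1-methyl-1H-pyrazol-4-yl, leaves the number in this assay within the scatter (a 1.2-fold higher number from compound 3 to compound 4 (0.07 log units; within the scatter)) and (a 1.1-fold higher number from compound 2 to compound 4 (0.03 log units; within the scatter)). The earlier compounds shown here only exchanged one ring for another, whereas the comparison with compound 1 isolates methoxy in place of hydrogen on the outer ring, and that step also stays within the scatter (a 1.4-fold higher number from compound 1 to compound 4 (0.16 log units; within the scatter)). No measurement available here offers an explanation for this flat result.

All the groups shown at this place are aromatic rings, so it remains open whether an amine, a carboxylic acid or a longer alkyl chain there would move the number beyond the scatter. The same question stands for a hydroxyl or a nitrile on the outer ring.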